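A few compounds are considered here, and "the series" means these few. Any claim that something is new, unique, unknown or untested is made for them only; others in the source may bear on it.

Values in a functional assay on MDA-MB-231 cells (Homo sapiens) for inhibition, read by sulforhodamine B assay, with a stated time of 48 h; a higher number here means a weaker inhibitor of growth, a lower number a stronger inhibitor of growth:
- compound 1 (`Cc1ccn2c(CN3CCCCC3)c(-c3ccccc3)nc2n1`): 30 nM
- compound 2 (`Cc1ccn2c(CN3CCCC3)c(-c3ccc(O)cc3)nc2n1`): 1200 nM
- compound 3 (`c1ccc(-c2nc3ncccn3c2CN2CCCCC2)cc1`): 30 nM

Compound 2 has the highest number of the three, beyond the scatter from both compound 1 and compound 3. The next compound is compound 4 (`Cc1ccn2c(CN3CCCC3)c(-c3ccccc3)nc2n1`), with hydrogen in place of hydroxy on an aromatic carbon. For the measured compounds named here, the one measured single-place step, no change at the digits printed from compound 1 to compound 3 (within the scatter), lies within the scatter but concerns a different change, so it sets no size here. Compound 2 also differs from compound 1 elsewhere, and compound 4 keeps that difference, so the whole gap cannot be assigned to hydroxy. With compound 1 at 30 nM as the closest measured relative, a clear fall in this assay is expected, probably stopping short of that value. The expected move is an estimated 10-fold lower number from compound 2 to compound 4 (1.00 log units; beyond the scatter). The estimate for compound 4 is 120 nM (range 30 nM to 600 nM).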

Compound 4, concentration for 50% growth inhibition: 4830 nM
The estimate for compound 4 lay 40-fold (1.60 log units) below the measured number, and the stated range ends below it.
By their numbers in this assay, from the lowest: compounds 1 and 3 (each within the scatter of the next); then compound 2; then compound 4.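

In this assay, hydrogen in place of hydroxy on the phenyl ring raises the number rather than lowering it (a 4.0-fold higher number from compound 2 to compound 4 (0.60 log units; beyond the scatter)), so within the pyrrolidin-1-yl pair the 4-hydroxyphenyl compound is the stronger inhibitor of growth. The larger step lies at the saturated amine ring, where pyrrolidin-1-yl replaces piperidin-1-yl (a 160-fold higher number from compound 1 to compound 4 (2.21 log units; beyond the scatter)). Going by these compounds, whether hydroxy has the same effect with piperidin-1-yl in place remains open, as does the outcome with methoxy or an amine at that ring position, or with morpholin-4-yl on the chain carbon. Nothing at hand accounts for either step.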